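This account rests on a few compounds, and the source may have more. Where it says the series, first, only, none or still open, it means among the compounds named here.

Compound 1 `COc1ccc(-c2cn3cc(C4=CCN(C(=O)C(C)(C)C)CC4)ccc3n2)cc1OC` gives 7100 nM in a functional assay on B16-F10 cells (Mus musculus) for antiproliferative activity, read by MTT assay, with a stated time of 48 h (on this read-out higher numbers stand for weaker inhibition and lower numbers for stronger inhibition), the lowest of the two numbers recorded; compound 2 `COc1ccc(-c2cn3cc(C4=CCN(C(=O)C5CC5)CC4)ccc3n2)cc1OC` gives 19400 nM. Within the data shown here, the one measured step, a 2.7-fold higher number from compound 1 to compound 2 (0.44 log units; beyond the scatter), replaced the tert-butyl on the carbonyl carbon with a small ring. Compound 3 `COc1ccc(-c2cn3cc(C4=CCN(C(=O)c5cccs5)CC4)ccc3n2)cc1OC` differs from compound 1 by thiophen-2-yl in place of tert-butyl on a carbonyl carbon, a change at the same carbonyl carbon, now to a five-membered aromatic ring with one hetero atom. Among the measured compounds shown here, only the step from compound 1 to compound 2 bears on it, and it was modest. Compound 3 is therefore expected at 12000 nM, within 5000 nM to 30000 nM, a step of a 1.7-fold higher number from compound 1 to compound 3 (0.23 log units; within the scatter).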

Compound 3, half-maximal inhibitory concentration: 19500 nM
For compound 3 the middle estimate is 1.6-fold (0.21 log units) below the measured one, and the stated range covers the measured number.
By their numbers in this assay, from the lowest: compound 1; then compounds 2 and 3 (each within the scatter of the next).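

Thiophen-2-yl on this carbonyl carbon gives a 2.7-fold higher number from compound 1 to compound 3 (0.44 log units; beyond the scatter), and set against cyclopropyl it gives a 1.0-fold higher number from compound 2 to compound 3 (0.00 log units; within the scatter), so a five-membered aromatic ring with one hetero atom and a small ring stand level here. Of the three groups, only tert-butyl, which has no ring, keeps the stronger inhibition of compound 1. Nothing available explains why the two rings match or why both fall short of tert-butyl. Going by these compounds, whether an open chain such as isopropyl, a phenyl ring or an amine on this carbonyl carbon would stand with compound 1 or with the two ring compounds remains open.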